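The compounds below may be only part of what the source reports. "The series", "measured", "known", "first", "only" and "open" are said of these compounds alone.

Measured compounds in a functional assay on HepG2 cells (Homo sapiens) for cytotoxicity, read by MTT assay, with a stated time of 72 h; on this read-out higher numbers stand for weaker inhibition and lower numbers for stronger inhibition:

Compound 1 `COc1cc(/C=N/NC(=O)Nc2cc3c(Nc4ccc(F)c(Cl)c4)ncnc3cc2O[C@H]2CCOC2)cc(OC)c1OC` gives 31200 nM.
Compound 2 `O=C(N/N=C/c1ccc(O)c(Br)c1)Nc1cc2c(Nc3ccc(F)c(Cl)c3)ncnc2cc1O[C@H]1CCOC1` gives 660 nM.
Compound 3 `COc1cc2ncnc(Nc3ccc(F)c(Cl)c3)c2cc1NC(=O)N/N=C/c1cc(OC)c(OC)c(OC)c1` gives 30100 nM.

Compounds 1 and 2 share a core and differ in one place: 3-bromo-4-hydroxyphenyl in place of 3,4,5-trimethoxyphenyl on a carbon with a double bond to nitrogen This change gave a 47-fold lower number from compound 1 to compound 2 (1.67 log units; beyond the scatter). Compounds 1 and 3 differ in their cores, and that difference is counted as follows: methyl in place of oxolan-3-yl on an oxygen on an aromatic ring Across this difference the numbers hardly move, as a 1.0-fold lower number from compound 1 to compound 3 (0.02 log units; within the scatter) shows, so compound 1 and compound 3 stand within the scatter of each other in this assay, while compound 2 stands far lower than either.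

Compound 4 `COc1cc2ncnc(Nc3ccc(F)c(Cl)c3)c2cc1NC(=O)N/N=C/c1ccc(O)c(Br)c1` has not yet been measured in this assay. It relates to compound 3 as compound 2 relates to compound 1: 3-bromo-4-hydroxyphenyl in place of 3,4,5-trimethoxyphenyl on a carbon with a double bond to nitrogen The place is described in the same words for both pairs, so this is the same change, made here on the core of compound 3 rather than on the core of compound 1. Since the two cores gave numbers within the scatter of each other, the same change is expected to produce a step of about the same size.

The step expected in this assay is a 43-fold lower number from compound 3 to compound 4 (1.63 log units; beyond the scatter), because the same change earlier gave a 47-fold lower number from compound 1 to compound 2 (1.67 log units; beyond the scatter). Compound 4 is therefore expected to give about 700 nM, with a likely range from 250 nM to 2500 nM.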

Compound 4, half-maximal inhibitory concentration: 23800 nM
For compound 4 the middle estimate is 34-fold (1.53 log units) below the measured one; measured number outside the range, above it.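

In this assay, putting 3-bromo-4-hydroxyphenyl in place of 3,4,5-trimethoxyphenyl did not carry over from one core to the other, since on the core of compound 3 it gave only a 1.3-fold lower number from compound 3 to compound 4 (0.10 log units; within the scatter): the same change on two cores in this assay, a 47-fold lower number (1.67 log units; beyond the scatter) from compound 1 to compound 2 and a 1.3-fold lower number (0.10 log units; within the scatter) from compound 3 to compound 4, 37-fold (1.57 log units) apart, beyond the scatter of two such steps

The same holds for the core difference itself, methyl in place of oxolan-3-yl on the oxygen, which mattered only where 3-bromo-4-hydroxyphenyl was present, giving a 36-fold higher number from compound 2 to compound 4 (1.56 log units; beyond the scatter): the same change on two cores in this assay, a 1.0-fold lower number (0.02 log units; within the scatter) from compound 1 to compound 3 and a 36-fold higher number (1.56 log units; beyond the scatter) from compound 2 to compound 4, 37-fold (1.57 log units) apart, beyond the scatter of two such steps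

The two changes therefore do not add up independently in this set, and the low number of compound 2 is seen only where 3-bromo-4-hydroxyphenyl and oxolan-3-yl stand together, but this rests on a single pair of aryl groups and a single pair of oxygen substituents in one cell assay, and it does not show why the two groups depend on each other or that other changes in the series would behave in the same way.

The compounds shown leave open whether the bromine, the hydroxyl or both are needed for the low number on the core of compound 1, which a chlorine in place of the bromine or a methoxy in place of the hydroxyl could address. They also leave open whether a longer chain or a chain ending in an amine on that oxygen would follow oxolan-3-yl or methyl.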